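Removing the Methoxy Group from a Weak Antiproliferative Compound

This account rests on a few compounds, and the source may have more. Where it says the series, first, only, none or still open, it means among the compounds named here.

Compound 1 `COc1ccc(C(F)(F)F)cc1Nc1ncc(C(F)(F)F)c(N2Cc3cccc(N(C)S(C)(=O)=O)c3C2)n1` was tested in a functional assay on A549 cells (Homo sapiens) for antiproliferative activity, read by spectrophotometry, with a stated time of 2 days; on this read-out lower numbers stand for stronger inhibition of growth and higher numbers for weaker inhibition of growth. In this assay compound 1 gives only a limit of the assay, > 30000 nM, not a number. Compound 2 `Cc1ccc(Nc2ncc(C(F)(F)F)c(N3Cc4cccc(N(C)S(C)(=O)=O)c4C3)n2)c(Cl)c1` likewise reaches only a limit in this assay, > 30000 nM. Compound 3 `Cc1ccc(Nc2ncc(C(F)(F)F)c(N3Cc4cccc(N(C)S(C)(=O)=O)c4C3)n2)c(C)c1` gives 20700 nM in this assay. The step that the two limits leave unreadable from compound 1 to compound 2 cannot be read, given (the limit of > 30000 nM in this assay, at which 2 of the 3 values shown sit). The steps of an at least 1.4-fold lower number from compound 1 to compound 3 (0.16 log units; that floor lies within the scatter) and an at least 1.4-fold lower number from compound 2 to compound 3 (0.16 log units; that floor lies within the scatter) are both small. Compound 4 `CN(c1cccc2c1CN(c1nc(Nc3cccc(C(F)(F)F)c3)ncc1C(F)(F)F)C2)S(C)(=O)=O` differs from compound 1 by hydrogen in place of methoxy on an aromatic carbon. Both exchanges of the group on that nitrogen gave nothing beyond the scatter, so compound 4 is expected to show no step beyond the scatter, a step that the limit leaves unreadable from compound 1 to compound 4. Compound 4 is estimated at 35000 nM, ranging from 15000 nM to 100000 nM, most likely again only a limit.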

Compound 4, concentration for 50% growth inhibition: > 30000 nM
Compound 4 gave a limit, no number (the forecaster's own chance of this, stated with the estimate: 60%); the middle value lies beyond the limit too.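

Removing the methoxy group leaves compound 4 at the limit of this assay, so this change at this position brought no measurable number. Within the data shown here, the one step that can be read is an at least 1.4-fold higher number from compound 3 to compound 4 (0.16 log units; that floor lies within the scatter), and it gives only a floor. The steps from compound 1 and from compound 2 to compound 4 cannot be read: the limit of > 30000 nM in this assay, at which 3 of the 4 values shown sit.

On these data alone, how far compounds 1, 2 and 4 lie beyond that limit remains open. The compounds shown also leave open how an amine or a carboxylic acid would read at the place of the methoxy group.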